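The source may report more compounds than this note shows. Statements on the series, on what has been measured and on what is new or still open speak of the compounds shown alone.

Compound 2 `Nc1ccc(-c2cc(=O)c3c(N)c(F)c(N)c(F)c3o2)cc1F` is the benchmark of this small set. In a functional assay on MCF7 cells (Homo sapiens) for cytotoxicity, read by neutral red uptake, with a stated time of 3 days (on this read-out lower numbers stand for stronger inhibition and higher numbers for weaker inhibition), compound 2 gives 7.7 nM, the lowest of the three numbers recorded. Compound 1 `Nc1ccc(-c2cc(=O)c3c(N)c(F)c(Cl)c(F)c3o2)cc1F` carries a chloro where compound 2 carries an amino. In this assay compound 1 gives 210 nM, and the step of a 27-fold lower number from compound 1 to compound 2 (1.44 log units; beyond the scatter). Within the data shown here, compound 3 `CCCCCCCCCC(=O)OCc1c(F)c(N)c2c(=O)cc(-c3ccc(N)c(F)c3)oc2c1F`, which carries a longer ester-bearing group at that same position, gives 100 nM in this assay; no single step is recorded between compound 2 and compound 3, but the two values show that compound 3 has the clearly higher number of the two.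

Compound 4 `CCCCCC(=O)NCc1c(F)c(N)c2c(=O)cc(-c3ccc(N)c(F)c3)oc2c1F` has not yet been measured. It differs from compound 2 by ((pentylcarbonyl)amino)methyl in place of amino on an aromatic carbon. Among the measured compounds shown here, the one recorded step at this position, from chloro to amino, was large, and compound 3 shows that a longer substituent at this position goes with a clearly higher number than the amino of compound 2. Compound 4 is therefore expected to lie between compound 2 and compound 3, with an expected step of a 7.8-fold higher number from compound 2 to compound 4 (0.89 log units; beyond the scatter) in the direction of weaker inhibition. The estimate for compound 4 in this assay is 60 nM, with a range from 15 nM to 250 nM.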

Compound 4, half-maximal inhibitory concentration: 340 nM
The estimate for compound 4 lay 5.7-fold (0.75 log units) below the measured number; the measured number lies above the stated range.
By their numbers in this assay, from the lowest: compound 2; then compound 3; then compounds 1 and 4 (each within the scatter of the next).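

In this assay, the low number of compound 2 does not survive replacement of its amino group by the much larger ((pentylcarbonyl)amino)methyl group (a 44-fold higher number from compound 2 to compound 4 (1.64 log units; beyond the scatter)). The same group set against the chloro group leaves no difference that can be read (a 1.6-fold higher number from compound 1 to compound 4 (0.21 log units; within the scatter)), so at this position compound 4 gains nothing over compound 1, and of the compounds compared here only the amino group of compound 2 goes with the low number. No measurement at hand accounts for this loss.

The compounds shown leave open whether the low number needs an amino group attached directly to the aromatic carbon, or whether a simple aminomethyl group would keep it. They also leave open how an acetylaminomethyl group, with its shorter chain, would compare with compound 4.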